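The source may report more compounds than this note shows. Statements on the series, on what has been measured and on what is new or still open speak of the compounds shown alone.

Compound 1 `O=[N+]([O-])c1c(CS(=O)(=O)c2ccccc2)nc2c(Nc3ccc(Cl)cc3)cc(Cl)cn12` has been tested in an ADME assay on HepG2 cells (Homo sapiens) for cytotoxicity, read by MTT assay, with a stated time of 72 h; on this read-out higher numbers stand for lower toxicity in this test and lower numbers for higher toxicity in this test. In this assay compound 1 gives > 3900 nM, which is a limit and not a number. Compound 2 `O=[N+]([O-])c1c(CS(=O)(=O)c2cccnc2)nc2c(Sc3ccc(Cl)cc3)cc(Cl)cn12` gives > 31200 nM in this assay, which is also a limit. Neither compound therefore has an exact number, and compound 1 is known only through its limit.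

Compound 3 `COc1ccc(Nc2cc(Cl)cn3c([N+](=O)[O-])c(CS(=O)(=O)c4ccccc4)nc23)cc1` has not yet been measured. It keeps the core of compound 1 and alters one group: methoxy in place of chloro on an aromatic carbon. This places methoxy in place of chloro on an aromatic carbon, para to a large group, so 4-chlorophenyl becomes 4-methoxyphenyl.

Among the compounds with values here, no pair of measured compounds shows what this swap does, so the expectation is only a cautious one. Compound 3 is expected to stay on the low-toxicity side, with a modest move toward higher numbers. That expectation rests on compound 1, whose entry of > 3900 nM is a limit. The expected size of the change is a step that the limit leaves unreadable from compound 1 to compound 3. For compound 3 the estimated value is 12000 nM, with an expected range from 4000 nM to 36000 nM.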

Compound 3, half-maximal cytotoxic concentration: > 3900 nM
Compound 3: a limit, no number; the forecaster's own chance of this, stated with the estimate: 55%; the middle value does not contradict the limit.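

Within the data shown here, compound 1 and compound 3 both stand only as limits in this assay, and no step between them can be read. The compounds shown leave open how far, and in which direction, methoxy in place of chloro on an aromatic carbon moves the half-maximal cytotoxic concentration, as none of them has an exact number.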